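The source may hold more compounds than are shown below. What is called first, only, known or untested is meant among the compounds shown, and "the series" means these compounds.

Measured so far:
- compound 1 `COc1cc(C(=O)c2ccc(OC)c(O)c2OC)cc(OC)c1O`: 13700 nM
- compound 2 `COc1cc(C(=O)c2ccc3c(c2)oc(=O)n3S(C)(=O)=O)cc(OC)c1OC`: 7790 nM

In a functional assay on SN12C cells (Homo sapiens) for cytotoxicity, read by sulforhodamine B assay, with a stated time of 48 h (on this read-out higher numbers stand for weaker inhibition of growth and lower numbers for stronger inhibition of growth), compound 1 stands within the scatter of compound 2, so the two cannot be separated. Compound 3 `COc1ccc(C(=O)c2cc(OC)c(OC)c(OC)c2)c(OC)c1O` differs from compound 1 by methyl in place of hydrogen on an oxygen on an aromatic ring, which is methyl in place of hydrogen on an oxygen on an aromatic ring, or hydroxy to methoxy. For the measured compounds named here, no measured step covers this change, so the expectation is uncertain. A step to a lower number, beyond the scatter, is expected in this assay. For compound 3 the estimated value is 2000 nM, with an expected range of 200 nM to 12000 nM. This estimate means an expected step of a 6.9-fold lower number from compound 1 to compound 3 (0.84 log units; beyond the scatter).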

Compound 3, concentration for 50% growth inhibition: 46.9 nM
Beside the measured number, compound 3's estimate is 43-fold (1.63 log units) above it, and the stated range ends above it.
By their numbers in this assay, from the lowest: compound 3; then compounds 2 and 1 (each within the scatter of the next).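

In this assay, for the compounds shown here, the change from hydroxy to methoxy gives a 290-fold lower number from compound 1 to compound 3 (2.47 log units; beyond the scatter) and is the first measured step at this place, on an oxygen on an aromatic ring. One added methyl on that oxygen is thus enough to move growth inhibition far beyond the scatter, so this place is strongly sensitive to this change. Nothing available explains the size of this step.

Still open, as far as these compounds go, is whether a longer chain such as ethyl or propyl on the same oxygen keeps this level of growth inhibition. From the compounds shown here alone, it is also open whether an amine or a carboxylic acid carried on that oxygen would do so.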